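Propoxy for methoxy on the tolerated series

A few compounds are considered here, and "the series" means these few. Any claim that something is new, unique, unknown or untested is made for them only; others in the source may bear on it.

Values in a functional assay on MDCK cells (Canis lupus familiaris) for inhibition; a higher number here means that more compound is tolerated, a lower number that less compound is tolerated:
- compound 1 `CCCOc1nc(CC2(c3ccccc3)CCCO2)cc(=O)n1C`: 170000 nM
- compound 2 `CCCOc1nc(CC2(C)CCCO2)cc(=O)n1C`: 860000 nM
- compound 3 `COc1nc(CC2CCCO2)cc(=O)n1C`: 1220000 nM

Compound 3 stands at the upper end of these numbers at 1220000 nM, within the scatter of compound 2 and clearly beyond the scatter from compound 1.

Compound 4 `CCCOc1nc(CC2CCCO2)cc(=O)n1C` differs from compound 3 by ethyl in place of hydrogen on a saturated chain carbon bound to an oxygen on an aromatic ring, which also reads as methoxy to propoxy.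

Within the data shown here, no measured step covers this change directly. The only one available, a 5.1-fold higher number from compound 1 to compound 2 (0.70 log units; beyond the scatter), is methyl in place of phenyl on a saturated ring carbon, so it bears on a different place and only shows that the series can move. More telling is that compound 2, which already carries propoxy, gives 860000 nM.

A small step is therefore expected, none beyond the scatter: a 1.3-fold lower number from compound 3 to compound 4 (0.11 log units; within the scatter). Compound 4 is estimated at 950000 nM, with an expected range of 450000 nM to 1800000 nM.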

Compound 4, half-maximal cytotoxic concentration: 1020000 nM
The estimate for compound 4 lay 1.1-fold (0.03 log units) below the measured number; the range from low to high includes it.
By their numbers in this assay, from the lowest: compound 1; then compounds 2, 4 and 3 (each within the scatter of the next).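

Methoxy to propoxy, read as ethyl in place of hydrogen on a saturated chain carbon bound to an oxygen on an aromatic ring, now has a direct reading in this assay (a 1.2-fold lower number from compound 3 to compound 4 (0.08 log units; within the scatter)), and the change stays within the scatter. Hydrogen in place of methyl on a saturated ring carbon also stays within the scatter (a 1.2-fold higher number from compound 2 to compound 4 (0.07 log units; within the scatter)), whereas hydrogen in place of phenyl there lies beyond it (a 6.0-fold higher number from compound 1 to compound 4 (0.78 log units; beyond the scatter)), so among these compounds only compound 1 stands apart. No measurement shown here accounts for these numbers.

Going by these compounds, whether a longer chain such as hexyloxy, or an amine in place of the propoxy group, would keep the number in this range remains open. On these data alone, the methoxy counterpart of compound 1 also remains open, so the change is untested alongside phenyl.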